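Replacing an ester-like group with a methyl-oxazole ring

This account rests on a few compounds, and the source may have more. Where it says the series, first, only, none or still open, it means among the compounds named here.

Measured so far:
compound 1, `CCCC(=O)C1=C(C)NC(=O)NC1c1ccco1`, 1%
compound 2, `CC1=C(C(=O)SC(C)C)C(c2ccco2)NC(=O)N1`, 5%

Both numbers come from an assay on membranes from CHO cells for displacement of a labelled ligand from adenosine receptor A1 (Homo sapiens), read by scintillation counting, with a stated time of 60 min, tested at 1 uM; a lower number here means less inhibition, a higher number more inhibition at the concentration tested (going by the name of the read-out). Compound 2 and compound 1 lie within the scatter of each other, as the step of a number 4 percentage points higher from compound 1 to compound 2 (within the scatter) shows; neither shows inhibition of note at the concentration tested.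

Compound 3 is `CC1=C(c2ncc(C)o2)C(c2ccco2)NC(=O)N1`. It differs from compound 2 in one place: 5-methyl-1,3-oxazol-2-yl in place of (isopropylsulfanyl)carbonyl on a double-bonded ring carbon. For the measured compounds named here, the only measured step, the one from compound 1 to compound 2, swaps groups on the carbonyl carbon and leaves this assay unchanged beyond the scatter. Going by the values given here, no measured step exchanges the whole carbonyl-bearing group for an aromatic ring, so there is no direct guide. With both measured compounds near zero, compound 3 is expected to remain near zero as well, with a step of a number 1 percentage points higher from compound 2 to compound 3 (within the scatter) expected. The estimate for compound 3 is 6%, ranging from -5% to 20%.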

Compound 3, a percentage reported as inhibition, at one concentration (the size of the read-out at that concentration, not a potency): 27%
Compound 3: middle estimate off by 21 percentage points, on the low side; measured number outside the range, above it.
By their numbers in this assay, from the lowest: compounds 1 and 2 (each within the scatter of the next); then compound 3.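

Unlike the swap on the carbonyl carbon, exchanging the whole carbonyl-bearing group for 5-methyl-1,3-oxazol-2-yl changes the result in this assay beyond the scatter: a number 22 percentage points higher from compound 2 to compound 3 (beyond the scatter), and a number 26 percentage points higher from compound 1 to compound 3 (beyond the scatter). The (isopropylsulfanyl)carbonyl group and the 5-methyl-1,3-oxazol-2-yl group have the same counts of heavy atoms and hydrogen-bond acceptors, so these counts do not separate them, although one has an aromatic ring and the other has none. No measurement here explains the rise.

On these data alone, whether the rise depends on the oxazole ring itself or on its methyl group remains open, and an oxazole without the methyl, or a thiazole in its place, would test this. Since the read-out comes from one concentration, it also leaves the potency of compound 3 open.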